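A few compounds are considered here, and "the series" means these few. Any claim that something is new, unique, unknown or untested is made for them only; others in the source may bear on it.

Measured compounds:
compound 1 `N#C/C(=C\N1CCN(C(=O)c2ccco2)C1=S)C(=O)c1ccccc1` with 23400 nM
compound 2 `O=CN1CCN(c2ccc(Cl)cc2)C1=S` with 15800 nM

In a functional assay on NCI-H322M cells (Homo sapiens) for inhibition, read by sulforhodamine B assay, with a stated time of 48 h (a higher number here means a weaker inhibitor of growth, a lower number a stronger inhibitor of growth), compound 2 gives 15800 nM, the lower of the two numbers, while compound 1 gives 23400 nM, a gap that stays within the scatter, so the two cannot be told apart. Compound 3 `O=CN1CCN(c2ccc(Cl)c(Cl)c2)C1=S` is not yet measured; it differs from compound 2 by chloro in place of hydrogen on an aromatic carbon. For the measured compounds named here, with no comparable step among the measured compounds, the expected change a 1.3-fold lower number from compound 2 to compound 3 (0.12 log units; within the scatter) is small, within the scatter. Compound 3 is estimated at 12000 nM, between 4000 nM and 35000 nM.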

Compound 3, concentration for 50% growth inhibition: 16800 nM
For compound 3 the middle estimate is 1.4-fold (0.15 log units) below the measured one; low and high end bracket the measured number.
By their numbers in this assay, from the lowest: compounds 2, 3 and 1 (each within the scatter of the next).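

In this assay, chloro in place of hydrogen on this aromatic carbon, ortho to a chloro group and meta to a group of 8 heavy atoms, gives a 1.1-fold higher number from compound 2 to compound 3 (0.03 log units; within the scatter). For the compounds shown here, this is the first step here between compounds that differ in one place, and it shows that at this position, chloro and hydrogen cannot be told apart. No measurement at hand offers an explanation for this result. Still open, from the compounds shown here alone, is whether a different group on this carbon, such as an amine or a carboxylic acid, would shift the number beyond the scatter.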